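This account rests on a few compounds, and the source may have more. Where it says the series, first, only, none or still open, it means among the compounds named here.

Measured so far:
compound 1 `Fc1ccc(Cn2cc(CCCOc3cccc4cccnc34)nn2)cc1`: 20.1 ug/mL
compound 2 `Clc1cc(Cl)c(Cn2cc(CCCOc3cccc4cccnc34)nn2)c(Cl)c1`: 2.8 ug/mL

Both compounds were run in a functional assay on PC-3 cells (Homo sapiens) for inhibition, read by sulforhodamine B assay, with a stated time of 48 h; a lower number here means a stronger inhibitor of growth, a higher number a weaker inhibitor of growth. Going by the values given here, compound 2 holds the lowest of the two numbers in this assay; the only other compound, compound 1, stands apart from it by the step of a 7.2-fold lower number from compound 1 to compound 2 (0.86 log units; beyond the scatter), which lies beyond the scatter.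

Compound 3 `c1cncc(CCCn2cc(CCCOc3cccc4cccnc34)nn2)c1` has not yet been measured. It differs from compound 2 by 2-(pyridin-3-yl)ethyl in place of 2,4,6-trichlorophenyl on a saturated chain carbon bound to an aromatic nitrogen. Among the compounds with values here, the single measured step at this position, a 7.2-fold lower number from compound 1 to compound 2 (0.86 log units; beyond the scatter), shows the number falling when a 4-fluorophenyl gives way to the 2,4,6-trichlorophenyl. Within the data shown here, no measured step reaches a 2-(pyridin-3-yl)ethyl, nor any group other than a phenyl at the saturated chain carbon bound to the aromatic nitrogen, so the new group has no direct precedent. The change from compound 2 to compound 3 takes away the group that went with the lowest number, so the expected direction is toward a higher number, of a size comparable to a 7.2-fold lower number from compound 1 to compound 2 (0.86 log units; beyond the scatter), though a single step gives little to fix the size. Compound 3 is therefore expected to give about 18 ug/mL in this assay, most likely between 6 ug/mL and 55 ug/mL, corresponding to the expected step of a 6.4-fold higher number from compound 2 to compound 3 (0.81 log units; beyond the scatter).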

Compound 3, concentration for 50% growth inhibition: 26.7 ug/mL
Estimate against measurement, compound 3: 1.5-fold (0.17 log units) below; low and high end bracket the measured number.
By their numbers in this assay, from the lowest: compound 2; then compounds 1 and 3 (each within the scatter of the next).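

In this assay, going by these compounds alone, the 2-(pyridin-3-yl)ethyl group, the first group at this position without a phenyl ring, does not retain the low number seen with 2,4,6-trichlorophenyl (a 9.5-fold higher number from compound 2 to compound 3 (0.98 log units; beyond the scatter)). Against 4-fluorophenyl, the same group gives a step that does not separate the two compounds (a 1.3-fold higher number from compound 1 to compound 3 (0.12 log units; within the scatter)), so two groups that differ in their ring and in their link to the aromatic nitrogen cannot be told apart in this read-out, and among the three compounds the low number goes with 2,4,6-trichlorophenyl alone. No accompanying data bear on why the number moves with this change.

The compounds shown leave open whether the low number depends on the three chlorine atoms or would also appear with another substituted phenyl, such as 2,4,6-trimethylphenyl or 2,4-dichlorophenyl. They also leave open how the ring and the chain contribute separately, which a 2-phenylethyl or a 2-(2,4,6-trichlorophenyl)ethyl group on the saturated chain carbon bound to the aromatic nitrogen would help to separate from the effect of the pyridine nitrogen.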